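Swapping the aryl ester substituent: chloro gives way to methoxy

The source may hold more compounds than are shown below. What is called first, only, known or untested is meant among the compounds shown, and "the series" means these compounds.

Three esters share a core and differ only in the aromatic acid part. Compound 1 `COc1cccc(C(=O)Oc2cc3c(cc2C)[C@@H](C(C)C)CC=C3C)c1` carries a 3-methoxyphenyl group and in a functional assay on PC-3 cells (Homo sapiens) for antiproliferative activity, read by sulforhodamine B assay, with a stated time of 48 h, tested at 50 uM (a higher number here means more inhibition at the concentration tested (going by the name of the read-out), a lower number less inhibition), compound 1 gives 16.3%. Compound 2 `Cc1cc2c(C(C)C)ccc(C)c2cc1OC(=O)c1cccc(C(F)(F)F)c1` carries a 3-(trifluoromethyl)phenyl group, and compound 2 gives 26.7%. Compound 3 `CC1=CC[C@H](C(C)C)c2cc(C)c(OC(=O)c3ccc(Cl)cc3)cc21` carries a 4-chlorophenyl group, and compound 3 gives 34.1%, the highest of the three numbers; compound 2 stands within the scatter of it, while compound 1 stands beyond it. Among the measured compounds shown here, the one single-point step among them runs a number 17.8 percentage points higher from compound 1 to compound 3 (beyond the scatter).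

Compound 4 `COc1ccc(C(=O)Oc2cc3c(cc2C)[C@@H](C(C)C)CC=C3C)cc1` is the next compound: methoxy in place of chloro on an aromatic carbon, on an aromatic carbon para to a large group. For the measured compounds named here, the measured step bears on this only in part, since it changes both the group and its place, yet it is the only guide. Because compound 1 with its methoxy group sits at 16.3%, a fall is expected for compound 4, of about a number 12.1 percentage points lower from compound 3 to compound 4 (beyond the scatter). Compound 4 is therefore estimated at 22%, with a range from 10% to 34%.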

Compound 4, a percentage reported as inhibition, at one concentration (the size of the read-out at that concentration, not a potency): 60.6%
For compound 4 the middle estimate is 38.6 percentage points below the measured one, outside the stated range (above it).
By their numbers in this assay, from the lowest: compound 1; then compounds 2 and 3 (each within the scatter of the next); then compound 4.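

In this assay, methoxy in place of chloro on an aromatic carbon para to a large group gives a number 26.5 percentage points higher from compound 3 to compound 4 (beyond the scatter) and so reverses the fall that compound 1 had suggested for a methoxy group. The position of the methoxy group on the ring therefore counts: 4-methoxyphenyl in place of 3-methoxyphenyl on the carbonyl carbon gives a number 44.3 percentage points higher from compound 1 to compound 4 (beyond the scatter) and is a large step, although the group itself stays the same. Nothing available explains why either change has this result.

On these data alone, how an amine, a hydroxyl group or a longer ethoxy chain would read at this same place remains open. So does whether a 3-chlorophenyl ester would fall short of compound 3 in the way that the 3-methoxyphenyl ester of compound 1 falls short of compound 4.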